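The compounds below may be only part of what the source reports. "The series", "measured", "known", "first", "only" and "open" are said of these compounds alone.

Measured in a functional assay on A549 cells (Homo sapiens) for cytotoxicity, read by MTT assay, with a stated time of 48 h; on this read-out lower numbers stand for stronger inhibition and higher numbers for weaker inhibition
- compound 1 `COc1ccc(/C=C/c2cc(OC)c(OC)c(OC)c2-c2ccc(OC)c(OC)c2)cc1` gives 28000 nM
- compound 2 `COc1cc(/C=C/c2ccc(C)cc2)c(-c2ccccc2)c(OC)c1OC` gives 54000 nM
- compound 3 `C=C(c1ccccc1)c1cc(OC)c(OC)c(OC)c1-c1ccccc1` gives 17000 nM

Compound 3 lies within the scatter of compound 1. Within the data shown here, the only measured step is a 3.2-fold lower number from compound 2 to compound 3 (0.50 log units; beyond the scatter) with 1-phenylethenyl in place of 2-(4-methylphenyl)ethenyl on an aromatic carbon. Compound 4 `C=C(c1ccc(C(F)(F)F)cc1)c1cc(OC)c(OC)c(OC)c1-c1ccccc1` differs from compound 3 by trifluoromethyl in place of hydrogen on an aromatic carbon, para to a large group (trifluoromethyl in place of hydrogen on an aromatic carbon). Among the measured compounds shown here, no measured compound carries trifluoromethyl, so the one step gives a modest scale but no direction. In this assay the expected result is a 1.1-fold lower number from compound 3 to compound 4 (0.05 log units; within the scatter) with no shift beyond the scatter. Compound 4 is estimated at 15000 nM (expected range 6000 nM to 40000 nM).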

Compound 4, half-maximal inhibitory concentration: 48000 nM
Compound 4: the middle estimate sits 3.2-fold (0.51 log units) below what was measured; measured number outside the range, above it.
By their numbers in this assay, from the lowest: compounds 3, 1, 4 and 2 (each within the scatter of the next, the first and the last beyond it).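

In this assay, phenyl to 4-(trifluoromethyl)phenyl gives a 2.8-fold higher number from compound 3 to compound 4 (0.45 log units; beyond the scatter), with the 1-phenylethenyl linkage unchanged. The earlier step changed the whole arm, whereas this one shows that a single replacement of hydrogen on this ring, para to a large group, moves the number beyond the scatter. No measured data on the compounds explain this step.

With trifluoromethyl the only replacement shown at this position, it remains open whether a single fluorine atom, a methoxy group, an amine or a carboxylic acid would shift the number in the same direction.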